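The source may hold more compounds than are shown below. What is called first, only, known or untested is meant among the compounds shown, and "the series" means these compounds.

Measured so far:
- compound 1 `OC(c1ncccc1F)C1(c2ccc(Cl)c(Cl)c2)CCC1`: 833 mL/min/kg
- compound 2 `O[C@H](c1ncccn1)C1(c2ccc(Cl)c(Cl)c2)CCC1`: 267 mL/min/kg

In an ADME assay on liver for metabolic stability, with Liver microsome (Homo sapiens) as the target, read by LC-MS, using microsomes, with a stated time of 5 h (a lower number here means slower removal, a higher number faster removal of the compound), compound 1 gives 833 mL/min/kg, the higher of the two numbers available and clearly beyond the scatter from the other, since compound 2 gives 267 mL/min/kg. The next compound to be tested, compound 3 `OC(c1ccc(F)cn1)C1(c2ccc(Cl)c(Cl)c2)CCC1`, has the same atoms as compound 1, joined differently. It carries 5-fluoropyridin-2-yl in place of 3-fluoropyridin-2-yl on a saturated chain carbon bound to an oxygen on a saturated carbon and a saturated ring carbon. The shared core is untouched.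

Within the data shown here, no measured pair shows this kind of change, so the expectation rests on little. Compound 1 at 833 mL/min/kg already stands high, and compound 2 at 267 mL/min/kg is the only other reference. A small shift toward slower removal in this assay therefore seems more likely than a further rise, but nothing beyond the scatter is expected. The expected change is a 1.3-fold lower number from compound 1 to compound 3 (0.13 log units; within the scatter). For compound 3 the estimated clearance is 620 mL/min/kg, with an expected range from 250 mL/min/kg to 1300 mL/min/kg.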

Compound 3, clearance: 767 mL/min/kg
Beside the measured number, compound 3's estimate is 1.2-fold (0.09 log units) below it, within the range that was stated.
By their numbers in this assay, from the lowest: compound 2; then compounds 3 and 1 (each within the scatter of the next).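

In this assay, 5-fluoropyridin-2-yl in place of 3-fluoropyridin-2-yl on a saturated chain carbon bound to an oxygen on a saturated carbon and a saturated ring carbon gives a 1.1-fold lower number from compound 1 to compound 3 (0.04 log units; within the scatter). Among these compounds, this is the first pair that differs in one place, and it shows that this rearrangement of the same atoms, with the shared core untouched, leaves the two compounds indistinguishable by this read-out. Nothing at hand offers an explanation for how closely the two fluoropyridines agree.

Going by these compounds, this single pair speaks only for these two fluoropyridin-2-yl groups, so it remains open how clearance would respond to a different group on that ring, such as an amine, a methoxy group or a nitrile. It also leaves open whether a change elsewhere in the molecule, such as a methyl ether in place of the hydroxyl group on the chain carbon, would move the number in this assay by more than the scatter.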